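A Methyl on the Aromatic Ring: What Toxicity to Expect

A few compounds are considered here, and "the series" means these few. Any claim that something is new, unique, unknown or untested is made for them only; others in the source may bear on it.

Compound 1, `C/C(C(=O)NC1CC1)=C(\C)c1ccccc1`, gives in a toxicity assay on the whole organism (strain Icem-CET (SPF Caw)) for cytotoxicity, with Mus musculus as the target (on this read-out higher numbers stand for an effect only at larger amounts of compound and lower numbers for an effect already at smaller amounts), a dose of 300 mg/kg.
Compound 2, `C/C(C(=O)NC1CC1)=C(/C)c1ccccc1`, gives in this assay a dose of 150 mg/kg.

Within the data shown here, compound 2 carries the smaller of the two numbers seen so far, but its only neighbour is separated from it by a 2.0-fold lower number from compound 1 to compound 2 (0.30 log units; within the scatter), a step that stays within the scatter and rests solely on (the fact that compounds 1 and 2 differ only in the configuration as drawn). The two measured compounds therefore stand together rather than apart.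

Compound 3, `C/C(C(=O)NC1CC1)=C(/C)c1ccc(C)cc1`, differs from compound 2 by methyl in place of hydrogen on an aromatic carbon, para to a large group. Among the measured compounds shown here, no measured step touches the aromatic ring; the single step available concerns only the configuration of the double bond and was itself within the scatter. For the measured compounds named here, nothing among the measured compounds therefore points toward a change of any size in this assay for this substitution.

Compound 3 is accordingly expected to show no change at the digits printed from compound 2 to compound 3 (within the scatter), a step not beyond the scatter. Compound 3 is estimated at 150 mg/kg, within a range from 60 mg/kg to 400 mg/kg.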

Compound 3, dose for half-maximal effect: 150 mg/kg
Compound 3: middle estimate and measured number agree at the digits printed; the range from low to high includes it.
By their numbers in this assay, from the lowest: compounds 2, 3 and 1 (each within the scatter of the next).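

Among these compounds, until now the only measured step concerned the configuration of the double bond, so the aromatic ring had not been probed at all. In this assay, the aromatic carbon para to a large group now has a step of its own: methyl in place of hydrogen there shows no change at the digits printed from compound 2 to compound 3 (within the scatter), so at this position and in the setting of compound 2, this one added carbon leaves the dose for half-maximal effect within the scatter of its parent. Among the compounds shown here, the information at hand about these compounds offers no explanation for this outcome, and the single pair of double-bond isomers does not bear on the ring.

From the compounds shown here alone, whether this tolerance extends beyond a single methyl remains open: a longer chain such as propyl, or a different group such as an amine or a carboxylic acid, on the same carbon might or might not leave the number where it stands. Going by these compounds, it is equally open whether methyl on another carbon of the ring, or the same methyl on compound 1, would give a step of similar size.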